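The source may hold more compounds than are shown below. What is called first, only, known or untested is meant among the compounds shown, and "the series" means these compounds.

In a functional assay on MCF7 cells (Homo sapiens) for antiproliferative activity, read by MTT assay, with a stated time of 24 h (a lower number here means a stronger inhibitor, a higher number a weaker inhibitor), compound 2 `CCn1c(C(=O)N[C@H](C)CO)ccc1C(CC)(CC)c1ccc(OCS(=O)(=O)c2ccccc2)c(C)c1` gives 10600 nM. Compound 3 `CCn1c(C(=O)N[C@H](CO)C(C)C)ccc1C(CC)(CC)c1ccc(OCS(=O)(=O)c2ccccc2)c(C)c1` gives 25500 nM, the higher of the two exact numbers available. Compound 1 `CCn1c(C(=O)N[C@@H](CC(=O)OC)C(=O)OC)ccc1C(CC)(CC)c1ccc(OCS(=O)(=O)c2ccccc2)c(C)c1` reads > 50000 nM, which is a limit of the assay and not a number. Compound 4 `CCn1c(C(=O)NCC(=O)O)ccc1C(CC)(CC)c1ccc(OCS(=O)(=O)c2ccccc2)c(C)c1` has yet to be measured. It departs from compound 3 by one change on an amide-type nitrogen, with carboxymethyl in place of 1-(hydroxymethyl)-2-methylpropyl (carboxymethyl in place of 1-(hydroxymethyl)-2-methylpropyl on an amide-type nitrogen).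

Three measured steps alter the group at this same place. Exchanging 1-(hydroxymethyl)ethyl for 1-(hydroxymethyl)-2-methylpropyl gave a 2.4-fold higher number from compound 2 to compound 3 (0.38 log units; beyond the scatter). Replacing 1,2-bis(methoxycarbonyl)ethyl with either of those groups gave an at least 4.7-fold lower number from compound 1 to compound 2 (0.67 log units; beyond the scatter) and an at least 1.9-fold lower number from compound 1 to compound 3 (0.29 log units; that floor lies within the scatter), and both of these sizes are only floors. Going by the values given here, none of the measured groups is carboxymethyl, so these steps suggest a plausible size but no firm direction. The expected result is no change beyond the scatter, with an estimated 1.2-fold higher number from compound 3 to compound 4 (0.07 log units; within the scatter), although a reading at the limit remains possible. Compound 4 is estimated at 30000 nM, with an expected range of 12000 nM to 70000 nM.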

Compound 4, half-maximal inhibitory concentration: 33100 nM
For compound 4 the middle estimate is 1.1-fold (0.04 log units) below the measured one; the measured number falls inside the stated range.
By their numbers in this assay, from the lowest: compound 2; then compounds 3 and 4 (each within the scatter of the next). At a limit, above all of these: compound 1.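

In this assay, carboxymethyl is the first group shown at this amide-type nitrogen that carries a carboxylic acid, and putting it in place of 1-(hydroxymethyl)-2-methylpropyl gives a 1.3-fold higher number from compound 3 to compound 4 (0.11 log units; within the scatter), so these two quite different groups cannot be told apart here. Against 1-(hydroxymethyl)ethyl, the same group gives a 3.1-fold higher number from compound 2 to compound 4 (0.49 log units; beyond the scatter), which leaves compound 2 as the only compound of the four whose steps to all the others lie beyond the scatter. The step of an at least 1.5-fold lower number from compound 1 to compound 4 (0.17 log units; that floor lies within the scatter) is only a floor, since compound 1 reads at a limit and not at a number: the limit of > 50000 nM in this assay, at which 1 of the 4 values shown sits.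

On these data alone, how the methyl ester of carboxymethyl, an amine or a longer chain ending in a carboxylic acid would read at this nitrogen remains open. So does whether any group here can bring the number below that of compound 2.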